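The source may report more compounds than this note shows. Statements on the series, on what has been measured and on what is new or still open speak of the compounds shown alone.

Working notes on the series. Compound 3 `COc1cc(Cl)cc(-c2nn(-c3cccc(NC(=O)Nc4ccc(Cl)c(Cl)c4)c3)cc2-c2ccncc2)c1` gives 95% in a functional assay on SF-268 cells (Homo sapiens) for inhibition, read by sulforhodamine B assay, with a stated time of 48 h, tested at 0.01 uM; on this read-out higher numbers stand for a weaker effect at the one concentration tested and lower numbers for a stronger effect; compound 1 `COc1cc(Cl)cc(-c2nn(-c3cccc(NC(=O)Nc4ccc(Cl)c(C(F)(F)F)c4)c3)cc2-c2ccncc2)c1` gives 95% and compound 2 `COc1cc(Cl)cc(-c2nn(-c3cccc(NC(=O)Nc4cc(C(F)(F)F)cc(C(F)(F)F)c4)c3)cc2-c2ccncc2)c1` gives 97%, so compound 3 stands level with compound 1 and its gap to compound 2 lies within the scatter. For the measured compounds named here, the only single-point step measured so far, no change at the digits printed from compound 1 to compound 3 (within the scatter), shows that a chloro in place of a trifluoromethyl on the aryl of the urea does not move the read-out.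

Compound 4 `COc1cc(Cl)cc(-c2nn(-c3cccc(NC(=O)Nc4cccc(C(F)(F)F)c4)c3)cc2-c2ccncc2)c1` is the next member, differing from compound 3 by 3-(trifluoromethyl)phenyl in place of 3,4-dichlorophenyl on an amide-type nitrogen. The step from compound 1 to compound 3 is the one that bears on this, since it also trades chloro for trifluoromethyl on the same aryl, and it was flat. All three measured numbers sit together, so no step beyond the scatter is expected in this assay.

Compound 4 is therefore expected to read 95%, between 87% and 101%, a step of no change at the digits printed from compound 3 to compound 4 (within the scatter) from compound 3 that is expected to lie within the scatter.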

Compound 4, a percentage reported as activity, at one concentration (the size of the read-out at that concentration, not a potency): 97%
Compound 4: middle estimate off by 2 percentage points, on the low side, and the stated range covers the measured number.
By their numbers in this assay, from the lowest: compounds 1, 3, 2 and 4 (each within the scatter of the next).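

In this assay, 3-(trifluoromethyl)phenyl in place of 3,4-dichlorophenyl on the amide-type nitrogen gives a number 2 percentage points higher from compound 3 to compound 4 (within the scatter). Taking a substituent off this aryl is a kind of change the earlier compounds did not offer: hydrogen in place of trifluoromethyl gives no change at the digits printed from compound 2 to compound 4 (within the scatter), and hydrogen in place of chloro gives a number 2 percentage points higher from compound 1 to compound 4 (within the scatter). At this one concentration, therefore, the read-out does not separate the aryl of compound 4 from those of compound 1, compound 2 and compound 3, whichever group is removed.

No measurement at hand offers a reason for this flat picture. Whether an unsubstituted phenyl, or an amine or a carboxylic acid on this aryl, would depart from these values remains open, as does any difference among these compounds at higher concentrations.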